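Methyl for Chloro on a Thiosemicarbazone Series

The source may report more compounds than this note shows. Statements on the series, on what has been measured and on what is new or still open speak of the compounds shown alone.

Measured compounds:
Compound 1 `O=C1Nc2cc(Cl)c(F)cc2/C1=N/NC(=S)Nc1ccc(Cl)cc1` gives 69000 nM in a functional assay on L1210 cells (Mus musculus), with a stated time of 48 h; on this read-out lower numbers stand for stronger inhibition and higher numbers for weaker inhibition.
Compound 2 `Cc1ccc(NC(=S)N/N=C2\C(=O)Nc3cc(Cl)c(F)cc32)cc1` gives 166000 nM in this assay.
Compound 3 `Cc1ccc(NC(=S)N/N=C2\C(=O)N(Cc3ccc(Cl)cc3)c3ccc(Br)cc32)cc1` gives >= 500000 nM in this assay.

Compound 1 and compound 2 share one core and differ by a single group: methyl in place of chloro on an aromatic carbon. This change gave a 2.4-fold higher number from compound 1 to compound 2 (0.38 log units; beyond the scatter), so the methyl compound inhibits the cells less strongly than the chloro compound.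

Compound 3 carries a second, larger core. The difference between the two cores is not broken down here. For compound 3 the value in this assay is a limit of the assay and not a number; the evidence shows (the limit of >= 500000 nM in this assay, at which 1 of the 3 values shown sits).

Compound 4 `Cc1ccc(CN2C(=O)/C(=N\NC(=S)Nc3ccc(C)cc3)c3cc(Br)ccc32)cc1` has not yet been measured. It stands to compound 3 as compound 2 stands to compound 1: methyl in place of chloro on an aromatic carbon. The place of the change is described in the same words for both pairs, so it is the same change on two different cores.

The expected size of the step from compound 3 to compound 4 is a step that the limit leaves unreadable from compound 3 to compound 4, resting on the step of a 2.4-fold higher number from compound 1 to compound 2 (0.38 log units; beyond the scatter) and on the limit of compound 3. Since compound 3 already sits at the limit and the earlier step raised the number, compound 4 is expected to return a limit too, with an estimated value of 700000 nM, ranging from 300000 nM to 3000000 nM.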

Compound 4, half-maximal inhibitory concentration: >= 500000 nM
Compound 4 was reported as a limit; the forecaster's own chance of this, stated with the estimate: 85%; the middle value does not contradict the limit.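

Compound 3 and compound 4 both stand at a limit of this assay and not at a number, so the step between them cannot be read: the limit of >= 500000 nM in this assay, at which 2 of the 4 values shown sit.

The compounds shown leave open whether going from 4-chlorobenzyl to 4-methylbenzyl changes inhibition of the cells at all, and whether it would match the step seen between compound 1 and compound 2.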